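A few compounds are considered here, and "the series" means these few. Any claim that something is new, unique, unknown or untested is made for them only; others in the source may bear on it.

Compound 1 `O=C(/C=C/c1ccc(F)cc1)c1ccccc1` was examined in a functional assay on RAW264.7 cells (Mus musculus) for inhibition, read by fluorescence, with stated times of 1 h, 24 h and 30 min; a lower number here means a stronger inhibitor, a higher number a weaker inhibitor. In this assay compound 1 gives only a limit of the assay, > 10000 nM. Compound 2 `O=C(/C=C/c1ccc(C(F)(F)F)cc1)c1ccccc1` carries trifluoromethyl in place of fluoro on an aromatic carbon. In this assay compound 2 likewise gives only a limit, > 10000 nM. The step that the two limits leave unreadable from compound 1 to compound 2 therefore cannot be read, since both values sit at the limit of > 10000 nM in this assay, at which 2 of the 2 values shown sit. Compound 3 `O=C(/C=C/c1ccc(OC(F)(F)F)cc1)c1ccccc1` differs from compound 2 by trifluoromethoxy in place of trifluoromethyl on an aromatic carbon. Among the measured compounds shown here, no measured step bears on this change in a readable way; the only step available, from compound 1 to compound 2, has no readable size. For the measured compounds named here, compound 2 stands at the limit of the assay, so no direction of step can be claimed beyond the scatter. The step that the limit leaves unreadable from compound 2 to compound 3 is estimated as essentially none. Compound 3 is therefore expected to give about 15000 nM, between 5000 nM and 50000 nM, most likely again reported only as a limit.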

Compound 3, half-maximal inhibitory concentration: > 10000 nM
Compound 3 ended at the assay's limit (the forecaster's own chance of this, stated with the estimate: 85%); the middle value does not contradict the limit.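

No step can be read among compound 1, compound 2 and compound 3 in this assay, since all three values are limits of the assay: the limit of > 10000 nM in this assay, at which 3 of the 3 values shown sit. The compounds shown leave open whether fluoro, trifluoromethyl and trifluoromethoxy differ at all in this assay.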